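Shortening the Amine Arm on the Shared Core

The source may report more compounds than this note shows. Statements on the series, on what has been measured and on what is new or still open speak of the compounds shown alone.

Measured so far:
compound 1 `CCOC(=O)c1cccc(-c2ccc(OC)cc2)c1`: 77%
compound 2 `CCOC(=O)c1cccc(-c2ccc(N(C)C)cc2)c1`: 87%
compound 3 `CCOC(=O)c1cccc(-c2ccc(CN3CCCCC3)cc2)c1`: 68%

In an assay on COS-7 cells for inhibition of patatin-like phospholipase domain-containing protein 2 (Mus musculus), tested at 200 uM (on this read-out higher numbers stand for more inhibition at the one concentration tested (going by the name of the read-out) and lower numbers for less inhibition), compound 3 gives the lowest of the three numbers. One of its two steps is a number 9 percentage points lower from compound 1 to compound 3 (within the scatter), which stays within the scatter, while the other is a number 19 percentage points lower from compound 2 to compound 3 (beyond the scatter), which lies beyond it.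

Compound 4 `CCOC(=O)c1cccc(-c2ccc(CN(C)C)cc2)c1` differs from compound 3 in one place: dimethylamino in place of piperidin-1-yl on a saturated chain carbon bound to an aromatic carbon. Read one bond further out, the (piperidin-1-yl)methyl group of compound 3 becomes (dimethylamino)methyl.

Going by the values given here, none of the measured steps makes this same change on a saturated chain carbon. The closest comparison is a number 19 percentage points lower from compound 2 to compound 3 (beyond the scatter), where (piperidin-1-yl)methyl replaced dimethylamino on an aromatic carbon, and a number 10 percentage points higher from compound 1 to compound 2 (within the scatter), a shift within the scatter. These speak to the groups involved but not to the position that changes here, so they give only weak guidance.

The account therefore expects for compound 4 a step of a number 4 percentage points higher from compound 3 to compound 4 (within the scatter), that is, no shift beyond the scatter in either direction. For compound 4 the expected value is 72%, within a range from 55% to 88%.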

Compound 4, a percentage reported as inhibition, at one concentration (the size of the read-out at that concentration, not a potency): 67%
Estimate against measurement, compound 4: 5 percentage points above; the measured number falls inside the stated range.
By their numbers in this assay, from the lowest: compounds 4, 3, 1 and 2 (each within the scatter of the next, the first and the last beyond it).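

In this assay, going by these compounds alone, the change of piperidin-1-yl to dimethylamino on a saturated chain carbon bound to an aromatic carbon gives a number 1 percentage points lower from compound 3 to compound 4 (within the scatter) and so offers the first direct reading at this position: here the ring and the open dimethylamino group cannot be told apart, even though the group shrinks from six heavy atoms to three. The other new comparisons show that placing the chain carbon in front of the amine matters more than which amine is carried, since (dimethylamino)methyl in place of dimethylamino on an aromatic carbon gives a number 20 percentage points lower from compound 2 to compound 4 (beyond the scatter) and thus a modest step, with compound 3 and compound 4 both standing beyond the scatter from compound 2. Set against methoxy on an aromatic carbon, (dimethylamino)methyl gives a number 10 percentage points lower from compound 1 to compound 4 (within the scatter) and is not separated from it on this read-out.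

As far as these compounds go, whether a longer chain carrying the dimethylamino group, a morpholin-4-yl group or a primary amine on the same saturated chain carbon would stand apart from compound 4 remains open. Nothing at hand explains why the numbers fall as they do.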